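Chloro to cyano on the aryl substituent of compound 1

A few compounds are considered here, and "the series" means these few. Any claim that something is new, unique, unknown or untested is made for them only; others in the source may bear on it.

Measured so far:
compound 1, `Cc1nc2cc(OC[C@H](O)CN3CCN(Cc4noc(-c5ccc(Cl)cc5)n4)CC3)ccc2s1`: 2270 nM
compound 2, `Cc1nc2cc(OC[C@H](O)CN3CCN(Cc4nnc(-c5ccc(C(F)(F)F)cc5)o4)CC3)ccc2s1`: 4800 nM
compound 3, `Cc1nc2cc(OC[C@H](O)CN3CCN(Cc4csc(-c5ccc(C(F)(F)F)cc5)n4)CC3)ccc2s1`: 1300 nM

Of the compounds shown here, three sharing one core have been measured in a functional assay on mitochondria from heart for inhibition of peroxisomal acyl-coenzyme A oxidase 1 (Rattus norvegicus); on this read-out lower numbers stand for stronger inhibition and higher numbers for weaker inhibition. Compound 1 stands second highest of the three numbers. Its nearest neighbour is compound 3, whose number is lower by an amount within the scatter, so no order between compound 1 and compound 3 can be read. Compound 2 lies furthest from compound 1, with a higher number beyond the scatter. Among the compounds with values here, none of these pairs differs in only one place, so the numbers show no single-change step.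

Compound 4, `Cc1nc2cc(OC[C@H](O)CN3CCN(Cc4noc(-c5ccc(C#N)cc5)n4)CC3)ccc2s1`, has not yet been measured in this assay. It differs from compound 1 in one place: cyano in place of chloro on an aromatic carbon. Within the data shown here, no measured pair shows what this exchange does on this core, so the expectation rests on compound 1 alone. Among the measured compounds shown here, with no step to lean on, the expected size of the step from compound 1 to compound 4 is estimated as a 1.3-fold higher number from compound 1 to compound 4 (0.12 log units; within the scatter), which is not beyond the scatter. For compound 4 the expected value in this assay is 3000 nM, with a range from 1000 nM to 9000 nM.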

Compound 4, half-maximal inhibitory concentration: 4410 nM
Beside the measured number, compound 4's estimate is 1.5-fold (0.17 log units) below it; measured number inside the range.
By their numbers in this assay, from the lowest: compounds 3, 1, 4 and 2 (each within the scatter of the next, the first and the last beyond it).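

In this assay, within the data shown here, the exchange of chloro for cyano on an aromatic carbon para to a large group gives the first single-change step, which runs a 1.9-fold higher number from compound 1 to compound 4 (0.29 log units; within the scatter) and leaves the 4-chlorophenyl and 4-cyanophenyl compounds indistinguishable on this read-out. The earlier compounds shown here differed from one another in more than one place, so none of them could isolate what a group at this position does alone; this pair shows that replacing chloro with cyano, with two heavy atoms in place of one and a hydrogen-bond acceptor added, produces no step beyond the scatter. No evidence bears on the reason for this result.

On these data alone, whether other groups at this position, such as an amine, a carboxylic acid or a methoxy group, would also stay within the scatter of compound 1 remains open. The compounds shown also hold only this one pair of chloro and cyano, so whether the same exchange would read alike on the scaffold of compound 2 or compound 3 is unknown.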